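Swapping vinyl for fluoro on a stable core

This account rests on a few compounds, and the source may have more. Where it says the series, first, only, none or still open, it means among the compounds named here.

Three compounds share one core. Compound 1 `C=CC(=O)Nc1cc(C(F)(F)F)cc(C(F)(F)F)c1` carries a (vinylcarbonyl)amino group; in an ADME assay for pharmacokinetics, read by HPLC, in phosphate buffer, with a stated time of 72 h, at pH 7.4, tested at 250 uM (a lower number here means that the compound disappears faster, a higher number that the compound lasts longer), compound 1 gives 4.2 h. Compound 2 `C=Cc1cc(C(F)(F)F)cc(C(F)(F)F)c1` carries a vinyl group instead, and in this assay compound 2 reaches only a limit, > 50 h. Compound 3 `N#Cc1cc(C(F)(F)F)cc(C(F)(F)F)c1` carries a cyano group, and in this assay compound 3 likewise reaches a limit, > 50 h. The steps of an at least 11-fold higher number from compound 1 to compound 2 (1.07 log units; beyond the scatter) and an at least 11-fold higher number from compound 1 to compound 3 (1.07 log units; beyond the scatter) are large, whereas a step that the two limits leave unreadable from compound 2 to compound 3 stays unreadable because of the limit of > 50 h in this assay, at which 2 of the 3 values shown sit. Compound 4 `Fc1cc(C(F)(F)F)cc(C(F)(F)F)c1` is not yet measured; it differs from compound 2 by fluoro in place of vinyl on an aromatic carbon. Going by the values given here, no measured step swaps vinyl for fluoro. Compound 4 is nevertheless expected to stay at the limit, estimated at 60 h within 20 h to 200 h. The expected step that the limit leaves unreadable from compound 2 to compound 4 is therefore none beyond the scatter.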

Compound 4, half-life: 11 h
Compound 4: the middle estimate sits 5.5-fold (0.74 log units) above what was measured, outside the stated range (below it).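

In this assay, this position does not keep every replacement at the limit: fluoro in place of vinyl gives an at least 4.5-fold lower number from compound 2 to compound 4 (0.65 log units; beyond the scatter), and fluoro in place of cyano gives an at least 4.5-fold lower number from compound 3 to compound 4 (0.65 log units; beyond the scatter). Fluoro in place of (vinylcarbonyl)amino still gives a 2.6-fold higher number from compound 1 to compound 4 (0.42 log units; beyond the scatter). Compound 4 therefore sits between compound 1 and the two compounds at the limit, so the group at this position clearly matters.

Compound 2 and compound 3 cannot be ordered against each other because both rest on one limit: the limit of > 50 h in this assay, at which 2 of the 4 values shown sit. As far as these compounds go, whether an amine or a carboxylic acid here would sit nearer compound 1 or compound 4 remains open.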